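A methoxyphenyl variant of a pyrimidine growth inhibitor

This account rests on a few compounds, and the source may have more. Where it says the series, first, only, none or still open, it means among the compounds named here.

Compound 3, with structure `Cc1ccc(Nc2nc(Nc3ccc(N4CCN(C)CC4)cn3)ncc2Cl)cc1`, was tested in a functional assay on Jurkat cells (Homo sapiens) for inhibition, read by CCK-8 assay, with a stated time of 48 h (a lower number here means a stronger inhibitor of growth, a higher number a weaker inhibitor of growth), and gives 30900 nM. Among the compounds with a numeric result it has the highest number, so it is the weaker of the two. Its closest relative is compound 2, `CN1CCN(c2ccc(Nc3ncc(Cl)c(NCc4ccc(C(F)(F)F)cc4)n3)nc2)CC1`, which in this assay gives 7960 nM; the step of a 3.9-fold higher number from compound 2 to compound 3 (0.59 log units; beyond the scatter) comes from putting 4-methylphenyl in place of 4-(trifluoromethyl)benzyl on a nitrogen on an aromatic ring. Compound 1, `Cc1ccccc1Nc1nc(NC2CC2)ncc1Cl`, reaches only a limit of the assay, > 100000 nM, and no number. The untested compound 4, `COc1cccc(Nc2nc(Nc3ccc(N4CCN(C)CC4)cn3)ncc2Cl)c1`, differs from compound 3 in one place: 3-methoxyphenyl in place of 4-methylphenyl on a nitrogen on an aromatic ring. For the measured compounds named here, no measured step changes this same group, so nothing here points to a move in either direction beyond the scatter. The step of a 1.0-fold lower number from compound 3 to compound 4 (0.01 log units; within the scatter) is therefore expected to stay small. For compound 4 the estimate in this assay is 30000 nM, with a range from 9000 nM to 100000 nM.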

Compound 4, concentration for 50% growth inhibition: 15800 nM
Beside the measured number, compound 4's estimate is 1.9-fold (0.28 log units) above it; the range from low to high includes it.
By their numbers in this assay, from the lowest: compounds 2, 4 and 3 (each within the scatter of the next, the first and the last beyond it). At a limit, above all of these: compound 1.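

The exchange of 4-methylphenyl for 3-methoxyphenyl on this nitrogen gives a 2.0-fold lower number from compound 3 to compound 4 (0.29 log units; within the scatter) in this assay, so these two groups cannot be told apart here, even though 3-methoxyphenyl carries a hydrogen-bond acceptor and 4-methylphenyl carries none. The exchange of the 4-(trifluoromethyl)benzyl group gives a 2.0-fold higher number from compound 2 to compound 4 (0.30 log units; within the scatter), which places compound 4 within the scatter of both of its relatives, although compound 2 and compound 3 lie beyond the scatter of each other. The clear gap seen earlier at this nitrogen therefore does not extend to compound 4, and no measurement shown bears on this result.

On these data alone, whether an amine or a carboxylic acid on this phenyl ring, or a longer chain on this nitrogen, would move the number beyond the scatter remains open. Also open is whether these groups would stay alike in any other cell line, since only one cell assay is shown.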